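This account rests on a few compounds, and the source may have more. Where it says the series, first, only, none or still open, it means among the compounds named here.

Of the compounds shown here, three sharing one core have been measured in an assay on cell membranes for displacement of a labelled ligand from Neuronal acetylcholine receptor; alpha4/beta2 (Rattus norvegicus); on this read-out higher numbers stand for weaker inhibition and lower numbers for stronger inhibition. Compound 1 `Clc1ccc(Nc2ccc(N3CC4CC(C3)N4)cn2)cc1` gives 2.49 nM. Compound 2 `Clc1ccc(Nc2cncc(N3CC4CC(C3)N4)c2)cc1` gives 0.118 nM, and compound 3 `O=[N+]([O-])c1ccc(Nc2cncc(N3CC4CC(C3)N4)c2)cc1` gives 0.0225 nM. Compound 2 thus holds the second highest of the three numbers; its nearest neighbour is compound 3, reached by a 5.2-fold lower number from compound 2 to compound 3 (0.72 log units; beyond the scatter), while compound 1 lies furthest from it, with a markedly higher number.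

Compound 4 `Clc1cccc(Nc2cncc(N3CC4CC(C3)N4)c2)c1` has not yet been measured. It differs from compound 2 in a single place: 3-chlorophenyl in place of 4-chlorophenyl on a nitrogen on an aromatic ring. Among the measured compounds shown here, the only measured step, from compound 2 to compound 3, exchanges one group for another, whereas the present change keeps the same atoms and merely rearranges them, so no measured step bears directly on it. In this assay compound 4 is therefore expected to stay close to compound 2, with only a small step, a 1.7-fold higher number from compound 2 to compound 4 (0.23 log units; within the scatter), expected towards a higher number. The estimate for compound 4 in this assay is 0.2 nM, within a range from 0.05 nM to 0.8 nM.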

Compound 4, inhibition constant: 0.124 nM
Beside the measured number, compound 4's estimate is 1.6-fold (0.21 log units) above it; the range from low to high includes it.
By their numbers in this assay, from the lowest: compound 3; then compounds 2 and 4 (each within the scatter of the next); then compound 1.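

In this assay, the step of a 1.1-fold higher number from compound 2 to compound 4 (0.02 log units; within the scatter) comes with 3-chlorophenyl in place of 4-chlorophenyl on a nitrogen on an aromatic ring, and it shows that these two chlorophenyl groups cannot be told apart on this read-out. The earlier step of a 5.2-fold lower number from compound 2 to compound 3 (0.72 log units; beyond the scatter) on this same group had exchanged chloro for nitro and said nothing about where the substituent stands, whereas this pair shows a shift of the chlorine alone with a result inside the scatter. No supporting information is available to explain this outcome.

The compounds shown leave open whether a methoxy group or an amine on the phenyl ring would likewise give matching numbers at these two placements. They also leave open whether 3-chlorophenyl and 4-chlorophenyl would match on the core of compound 1.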